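Adding an ethoxycarbonyl group to compound 3

The source may hold more compounds than are shown below. What is called first, only, known or untested is meant among the compounds shown, and "the series" means these compounds.

- Compound 1 `CCOC(=O)C[n+]1cccc(O)c1`: > 200000 nM (a limit, not a number)
- Compound 2 `CCOC(=O)C[n+]1cccc2cc(O)ccc21`: > 200000 nM (a limit, not a number)
- Compound 3 `C[n+]1cccc(OP(=O)([O-])OC[C@H]2O[C@@H](n3cc(F)c(=O)[nH]c3=O)C[C@@H]2OC(=O)c2ccccc2)c1`: 3150 nM

All three were tested in a functional assay on U-118-MG cells (Homo sapiens) for cytotoxicity, read by MTT assay, with a stated time of 48 h; a lower number here means a stronger inhibitor, a higher number a weaker inhibitor. Compounds 1 and 2 both sit at one limit: the limit of > 200000 nM in this assay, at which 2 of the 3 values shown sit. Compound 3 alone has a true number, 3150 nM, so nothing measured can be ranked against it with precision.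

Compound 4 `CCOC(=O)C[n+]1cccc(OP(=O)([O-])OC[C@H]2O[C@@H](n3cc(F)c(=O)[nH]c3=O)C[C@@H]2OC(=O)c2ccccc2)c1` differs from compound 3 in one place, with ethoxycarbonyl in place of hydrogen on a saturated chain carbon bound to an aromatic nitrogen. Going by the values given here, no measured pair shows this change, so the expectation starts from compound 3 at 3150 nM and assumes little movement. The expected step is a 1.1-fold higher number from compound 3 to compound 4 (0.05 log units; within the scatter), with no clear direction beyond the usual scatter. For compound 4 the estimated value is 3500 nM, with an expected range from 1000 nM to 15000 nM.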

Compound 4, half-maximal inhibitory concentration: 1540 nM
Compound 4: middle estimate off by 2.3-fold (0.36 log units), on the high side; the range from low to high includes it.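

Within this assay the ethoxycarbonyl group on a saturated chain carbon bound to an aromatic nitrogen gives a 2.0-fold lower number from compound 3 to compound 4 (0.31 log units; beyond the scatter) and so provides the first measured step in this set. Going by these compounds alone, this place therefore takes a group of this size with a modest gain rather than a loss in this cell test, where earlier only a single true number stood.

As far as these compounds go, whether a carboxylic acid or a longer chain at this place would move the number further stays open. No measurement shown gives a reason for this step.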